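The source may report more compounds than this note shows. Statements on the series, on what has been measured and on what is new or still open speak of the compounds shown alone.

Three compounds share one core and differ only in the group attached to a carbonyl carbon whose other neighbour is an amide-type nitrogen. In a functional assay on HUVEC cells (Homo sapiens) for inhibition, tested at 5 ug/mL (on this read-out higher numbers stand for a stronger effect at the one concentration tested and lower numbers for a weaker effect), compound 1 `COc1cc(/C=C/C(=O)c2cccc(NC(=O)c3ccco3)c2)ccc1O` gives 82%, compound 2 `COc1cc(/C=C/C(=O)c2cccc(NC(=O)c3ccc(Cl)cc3Cl)c2)ccc1O` gives 51%, and compound 3 `COc1cc(/C=C/C(=O)c2cccc(NC(=O)c3ccc(Cl)c(Cl)c3)c2)ccc1O` gives 5%. Compound 3 therefore stands lowest of the three numbers; its nearest neighbour is compound 2 and its furthest is compound 1, and both gaps lie beyond the scatter.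

Compound 4 `COC(=O)C(=O)Nc1cccc(C(=O)/C=C/c2ccc(O)c(OC)c2)c1` has not yet been measured. It differs from compound 3 in one place: methoxycarbonyl in place of 3,4-dichlorophenyl on a carbonyl carbon.

Going by the values given here, no measured step brings in a methoxycarbonyl, so the expectation rests on what the three steps reveal about this position. Leaving furan-2-yl gave a number 31 percentage points lower from compound 1 to compound 2 (beyond the scatter) and a number 77 percentage points lower from compound 1 to compound 3 (beyond the scatter), and between the two dichlorophenyl groups there was a number 46 percentage points lower from compound 2 to compound 3 (beyond the scatter). Every change at this carbonyl carbon moved the read-out by a large amount. With compound 3 at 5%, the bottom of the range, a further fall has little room, whereas a rise is possible. A rise beyond the scatter is expected, a number 40 percentage points higher from compound 3 to compound 4 (beyond the scatter), though its size is uncertain. Compound 4 is estimated at 45%, within 10% to 80%.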

Compound 4, a percentage reported as inhibition, at one concentration (the size of the read-out at that concentration, not a potency): 20%
Compound 4: the middle estimate sits 25 percentage points above what was measured, within the range that was stated.
By their numbers in this assay, from the lowest: compound 3; then compound 4; then compound 2; then compound 1.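

In this assay, going by these compounds alone, methoxycarbonyl, the first group in this set with no ring, gives a number 15 percentage points higher from compound 3 to compound 4 (beyond the scatter) and so shows that a ring on this carbonyl carbon is not needed to reach a number above that of compound 3. The same change gives a number 31 percentage points lower from compound 2 to compound 4 (beyond the scatter) and also a number 62 percentage points lower from compound 1 to compound 4 (beyond the scatter) and places the ringless compound 4 among the ring-bearing compounds, so having a ring or lacking one does not by itself sort these four numbers. Nothing measured here explains why these groups differ in this way.

The compounds shown leave open whether the result depends on the whole methoxycarbonyl group or on a part of it, which a carboxylic acid or an ethoxycarbonyl group in its place would help to separate. They also leave open whether the high number of compound 1 is specific to furan-2-yl or extends to other rings, such as thiophen-2-yl or an unsubstituted phenyl.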